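A Fluoro Substituent on the Central Ring of Compound 2

The source may report more compounds than this note shows. Statements on the series, on what has been measured and on what is new or still open speak of the compounds shown alone.

Measured compounds in this study:
compound 1, `CNC(=O)c1cc(Oc2ccc(NC(=O)c3cc(-c4ccc(C)cc4)ncn3)cc2)ccn1`: > 100000 nM
compound 2, `CNC(=O)c1cc(Oc2ccc(NC(=O)c3cc(-c4ccc(Br)cc4)ncn3)cc2)ccn1`: > 100000 nM
compound 3, `CCc1ccc(-c2cc(C(=O)Nc3ccc(Oc4ccnc(C(=O)NC)c4)cc3)ncn2)cc1`: 13300 nM

In a functional assay on A549 cells (Homo sapiens) for cytotoxicity, read by MTT assay, with a stated time of 72 h (on this read-out lower numbers stand for stronger inhibition and higher numbers for weaker inhibition), compound 1 reports only a limit of the assay, > 100000 nM, not a number. Compound 2 likewise reports only a limit, > 100000 nM. Compound 3 gives a number, 13300 nM. Among the compounds with values here, compound 2 therefore stands at the limit of > 100000 nM in this assay, at which 2 of the 3 values shown sit, and the only readable step leading away from it is an at least 7.5-fold lower number from compound 2 to compound 3 (0.87 log units; beyond the scatter), while a step that the two limits leave unreadable from compound 1 to compound 2. Compound 4, `CNC(=O)c1cc(Oc2ccc(NC(=O)c3cc(-c4ccc(Br)cc4)ncn3)cc2F)ccn1`, differs from compound 2 by fluoro in place of hydrogen on an aromatic carbon; the new atom sits on an aromatic carbon of a six-membered aromatic ring of carbon only, ortho to a (2-(methylcarbamoyl)pyridin-4-yl)oxy group and meta to a large group. Neither measured step touches this part of the shared core: both readable steps, an at least 7.5-fold lower number from compound 1 to compound 3 (0.87 log units; beyond the scatter) and an at least 7.5-fold lower number from compound 2 to compound 3 (0.87 log units; beyond the scatter), alter a group on a different aromatic carbon, and no fluoro substitution has been measured at all. Within the data shown here, no measured step therefore bears on the change, and the expectation rests only on compound 2 being at a limit. Compound 4 is expected to show a number no higher from compound 2 to compound 4 (the limit leaves the size open), with the assay most likely again reporting only a limit. The estimate for compound 4 is 100000 nM, between 30000 nM and 300000 nM.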

Compound 4, half-maximal inhibitory concentration: > 100000 nM
Compound 4 was reported as a limit; the forecaster's own chance of this, stated with the estimate: 70%; the middle value sits exactly at the limit.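

In this assay compound 4 gives only a limit of the assay, > 100000 nM. Within the data shown here, compound 2 likewise gives only a limit, so no step from compound 2 to compound 4 can be read. The compounds shown leave open whether fluoro in place of hydrogen on this aromatic carbon changes the number at all.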